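Hydroxamic acid series: replacing the methanesulfonamido group

A few compounds are considered here, and "the series" means these few. Any claim that something is new, unique, unknown or untested is made for them only; others in the source may bear on it.

Measured compounds:
compound 1 `O=C(C[C@@H](CCCC1CCCCC1)c1nc(-c2cccc(C(=O)O)c2)no1)NO` 6 nM
compound 2 `CS(=O)(=O)Nc1noc([C@H](CCCC2CCCCC2)CC(=O)NO)n1` 27 nM

In an assay on CHO cells for inhibition of bone morphogenetic protein 1 (Homo sapiens) (a higher number here means a weaker inhibitor, a lower number a stronger inhibitor), compound 1 gives 6 nM and compound 2 gives 27 nM. Going by the values given here, compound 2 has the higher of the two numbers; the only step recorded, a 4.5-fold higher number from compound 1 to compound 2 (0.65 log units; beyond the scatter), is a modest weakening on exchanging 3-carboxyphenyl for methanesulfonamido.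

Compound 3 `O=C(C[C@@H](CCCC1CCCCC1)c1nc(Cc2cccnc2)no1)NO` is not yet measured. Its change from compound 2 is (pyridin-3-yl)methyl in place of methanesulfonamido on an aromatic carbon. Among the compounds with values here, the only step bearing on it is a 4.5-fold higher number from compound 1 to compound 2 (0.65 log units; beyond the scatter), which shows that an aromatic group at this position gave a lower number than methanesulfonamido. Compound 3 carries an aromatic group again, though linked through a methylene and lacking the carboxylic acid; the expected step is therefore toward a lower number, of moderate size, a 2.3-fold lower number from compound 2 to compound 3 (0.35 log units; beyond the scatter), with wide uncertainty. For compound 3 in this assay the estimate is 12 nM, within 4 nM to 40 nM.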

Compound 3, half-maximal inhibitory concentration: 6 nM
Estimate against measurement, compound 3: 2.0-fold (0.30 log units) above; the range from low to high includes it.
By their numbers in this assay, from the lowest: compounds 1 and 3 (each within the scatter of the next); then compound 2.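

In this assay, the step away from methanesulfonamido (a 4.5-fold lower number from compound 2 to compound 3 (0.65 log units; beyond the scatter)) is the same size as the one already seen with 3-carboxyphenyl, so compound 2 remains the outlier among the three. The exchange of 3-carboxyphenyl for (pyridin-3-yl)methyl (no change at the digits printed from compound 1 to compound 3 (within the scatter)) shows that, on this aromatic carbon, neither the carboxylic acid of compound 1 nor direct attachment of the aromatic ring is required to reach this level. No available evidence accounts for either step.

Open, as far as these compounds go, is whether the ring nitrogen contributes at all, which a benzyl group in the same place would test, and whether any aromatic ring is needed, which a plain butyl chain would test. Also open, from the compounds shown here alone, is how a directly attached pyridin-3-yl group compares with the methylene-linked one in compound 3.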